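The compounds below may be only part of what the source reports. "The series", "measured", "known", "first", "only" and "open" are said of these compounds alone.

Compound 1 `O=C(Nc1ccc(F)cc1)N[C@H]1CC[C@H](Oc2ccc(F)cc2)CC1`: 20000 nM
Compound 2 `O=C(Nc1ccccc1[N+](=O)[O-])N[C@H]1CC[C@H](Oc2ccc(F)cc2)CC1`: 3500 nM
Compound 3 `O=C(Nc1ccccc1Br)N[C@H]1CC[C@H](Oc2ccc(F)cc2)CC1`: 7700 nM

In a functional assay on CRL2813 cells (Homo sapiens) for cytotoxicity, read by sulforhodamine B assay, with a stated time of 5 days (on this read-out lower numbers stand for stronger inhibition and higher numbers for weaker inhibition), compound 1 stands highest of the three numbers. Two steps lead down from it: a 5.7-fold lower number from compound 1 to compound 2 (0.76 log units; beyond the scatter) and a 2.6-fold lower number from compound 1 to compound 3 (0.41 log units; beyond the scatter); between the other pair there is a 2.2-fold higher number from compound 2 to compound 3 (0.34 log units; beyond the scatter). Compound 4 `O=C(Nc1cccc(Br)c1)N[C@H]1CC[C@H](Oc2ccc(F)cc2)CC1` differs from compound 1 by 3-bromophenyl in place of 4-fluorophenyl on an amide-type nitrogen. Going by the values given here, the step that bears most directly on it is a 2.6-fold lower number from compound 1 to compound 3 (0.41 log units; beyond the scatter), where a bromophenyl also replaced the 4-fluorophenyl, and the step of a 5.7-fold lower number from compound 1 to compound 2 (0.76 log units; beyond the scatter) points the same way; no measured step tests the 3-bromophenyl itself. A modest lower number is therefore expected for compound 4. The expected step is a 2.5-fold lower number from compound 1 to compound 4 (0.40 log units; beyond the scatter). Compound 4 is estimated at 8000 nM, with a range of 3000 nM to 20000 nM.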

Compound 4, half-maximal inhibitory concentration: 6200 nM
Beside the measured number, compound 4's estimate is 1.3-fold (0.11 log units) above it, within the range that was stated.
By their numbers in this assay, from the lowest: compounds 2, 4 and 3 (each within the scatter of the next, the first and the last beyond it); then compound 1.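

In this assay, the 3-bromophenyl group on the amide-type nitrogen also gives a lower number than the 4-fluorophenyl group, with a 3.2-fold lower number from compound 1 to compound 4 (0.51 log units; beyond the scatter). The 2-bromophenyl and 3-bromophenyl groups cannot be told apart, with a 1.2-fold lower number from compound 3 to compound 4 (0.09 log units; within the scatter), and neither can the 2-nitrophenyl and 3-bromophenyl groups, with a 1.8-fold higher number from compound 2 to compound 4 (0.25 log units; within the scatter). Nothing available explains these numbers. The compounds shown leave open how a plain phenyl or a 4-bromophenyl group would compare with the 4-fluorophenyl group. They also leave open what an amine or a carboxylic acid on this ring would do.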